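Phenyl for methyl on the core nitrogen, and the inhibition in this assay

This account rests on a few compounds, and the source may have more. Where it says the series, first, only, none or still open, it means among the compounds named here.

Compound 1 `Cn1c(=O)c(C(=O)NCCN)c(O)c2ccccc21`: 99.5%
Compound 2 `NCCNC(=O)c1c(O)c2ccccc2n(-c2ccccc2)c1=O`: 82.3%
Compound 3 `Cn1c(=O)c(C(=O)NCCCCCCNC(=O)CCCCC2CCSS2)c(O)c2ccccc21`: 79.1%

In an assay on isolated protein for inhibition of seed linoleate 13S-lipoxygenase-1 (Glycine max), tested at 0.1 mM (a lower number here means less inhibition, a higher number more inhibition at the concentration tested (going by the name of the read-out)), compound 1 gives 99.5%, the highest of the three numbers. Compound 2 gives 82.3%, and the step of a number 17.2 percentage points lower from compound 1 to compound 2 (beyond the scatter) comes from phenyl in place of methyl on an aromatic nitrogen. Compound 3 gives 79.1%; its difference from the core of compound 1 is not broken down here.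

Compound 4 `O=C(CCCCC1CCSS1)NCCCCCCNC(=O)c1c(O)c2ccccc2n(-c2ccccc2)c1=O` is not yet measured. It differs from compound 3 by phenyl in place of methyl on an aromatic nitrogen, the same kind of change as that from compound 1 to compound 2, though the place is meta to a large group rather than meta to a (2-aminoethyl)carbamoyl group. Resting on the step of a number 17.2 percentage points lower from compound 1 to compound 2 (beyond the scatter), a step of about a number 17.1 percentage points lower from compound 3 to compound 4 (beyond the scatter) is expected from compound 3 to compound 4. Compound 4 is therefore estimated at 62%, between 42% and 80%.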

Compound 4, a percentage reported as inhibition, at one concentration (the size of the read-out at that concentration, not a potency): 64%
Compound 4: middle estimate off by 2 percentage points, on the low side, and the stated range covers the measured number.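

In this assay the change of methyl to phenyl on the aromatic nitrogen gives a number 15.1 percentage points lower from compound 3 to compound 4 (beyond the scatter) and, on this evidence, carries over from one core to the other with its size preserved: the same change on two cores in this assay, a number 17.2 percentage points lower (beyond the scatter) from compound 1 to compound 2 and a number 15.1 percentage points lower (beyond the scatter) from compound 3 to compound 4, 2.1 percentage points apart, within the scatter of two such steps. For the compounds shown here, this agreement rests on only two matched pairs, both read at a single concentration, so it says nothing about potency. Nor does it show that the step would hold on any other core in the series.

The compounds shown leave open how an ethyl or benzyl group on that nitrogen would compare with methyl and phenyl. They also leave open whether the step would keep its size with a shorter chain or a carboxylic acid in the large group.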